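This account rests on a few compounds, and the source may have more. Where it says the series, first, only, none or still open, it means among the compounds named here.

Measured compounds:
compound 1 `COc1ccc2nc(-c3ccc(N/C=C\C(=O)c4ccc(OC)c(O)c4)c(C)c3)sc2c1` gives 14000 nM
compound 2 `COc1cc(OC)c2sc(-c3ccc(N/C=C\C(=O)c4ccc(OC)c(F)c4)c(C)c3)nc2c1` gives 13300 nM
compound 3 `COc1ccc2nc(-c3ccc(N/C=C\C(=O)c4ccc(OC)c([N+](=O)[O-])c4)c(C)c3)sc2c1` gives 17600 nM

All three were read in a functional assay on MDA-MB-231 cells (Homo sapiens) for antiproliferative activity, read by sulforhodamine B assay, with a stated time of 48 h; on this read-out higher numbers stand for weaker inhibition and lower numbers for stronger inhibition. Compound 1 stands among three numbers that lie close together: its nearest neighbour is compound 2 and its furthest is compound 3, and both gaps are within the scatter. Within the data shown here, the one step measured between compounds that differ in a single place, a 1.3-fold higher number from compound 1 to compound 3 (0.10 log units; within the scatter), is also within the scatter.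

Compound 4 `COc1ccc2nc(-c3ccc(N/C=C\C(=O)c4ccc(OC)c(O)c4)cc3)sc2c1` has not been measured. It differs from compound 1 in one place: hydrogen in place of methyl on an aromatic carbon. Among the measured compounds shown here, no measured step removes a methyl, so nothing among the measured compounds speaks directly to this change. For the measured compounds named here, the only available step, a 1.3-fold higher number from compound 1 to compound 3 (0.10 log units; within the scatter), concerns a different group on a different ring and shows only that a single change has so far stayed within the scatter. On that basis compound 4 is expected to move no further than the scatter from compound 1, no change at the digits printed from compound 1 to compound 4 (within the scatter). Compound 4 is therefore estimated at 14000 nM, with a range from 6000 nM to 32000 nM.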

Compound 4, half-maximal inhibitory concentration: 18900 nM
The estimate for compound 4 lay 1.4-fold (0.13 log units) below the measured number, and the stated range covers the measured number.
By their numbers in this assay, from the lowest: compounds 2, 1, 3 and 4 (each within the scatter of the next).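

Swapping the methyl for hydrogen on this aromatic carbon, ortho to one large group and meta to another, gives in this assay a 1.4-fold higher number from compound 1 to compound 4 (0.13 log units; within the scatter). Among these compounds, this is the first reading at this position, and it shows that in this pair the methyl can be lost without the number leaving the scatter, so the methyl is not needed to hold activity at this level. Nothing available explains why this change has so small an effect on the result.

The compounds shown leave open whether an amine, a carboxylic acid or an ethyl chain on this same carbon would carry the number beyond the scatter. They also leave open whether hydrogen in place of methyl would stay within the scatter alongside the fluoro or nitro group on the other ring.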